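A few compounds are considered here, and "the series" means these few. Any claim that something is new, unique, unknown or untested is made for them only; others in the source may bear on it.

Measured so far:
compound 1 `Cc1ccc(/C=C/C(=O)Nc2ccc3nc(N4CCC(O)(C5CC5)CC4)nc(C)c3c2)cc1`: 107 nM
compound 2 `Cc1nc(N2CCC(N3C(=O)CCC3=O)CC2)nc2ccc(NC(=O)/C=C/c3ccc(OC(F)(F)F)cc3)cc12`: 35 nM

Both numbers come from a functional assay on CHO-K1 cells for antagonist activity at melanin-concentrating hormone receptor 1 (Homo sapiens), read by inositol phosphate accumulation, with stated times of 10 min and 45 min; a higher number here means a weaker inhibitor, a lower number a stronger inhibitor. Of the two, compound 2 stands at the lower number; compound 1 gives the higher number, and the gap between them lies beyond the usual scatter of repeated runs. Among the compounds with values here, compound 1 and compound 2 differ in more than one place, so no single step can be read from this pair; their two values show only that compound 2 is the more potent of the two.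

Compound 3 `Cc1nc(N2CCC(N3CCN(C)C3=O)CC2)nc2ccc(NC(=O)/C=C/c3ccc(OC(F)(F)F)cc3)cc12` has not yet been measured. It keeps the whole of compound 2 apart from one change: 3-methyl-2-oxoimidazolidin-1-yl in place of 2,5-dioxopyrrolidin-1-yl on a saturated ring carbon. The group that leaves and the group that enters are both five-membered non-aromatic rings without a hydrogen-bond donor and without net charge, set on the same saturated ring carbon. With no measured step of this kind in the series, the expectation for compound 3 is a step of a 1.1-fold higher number from compound 2 to compound 3 (0.06 log units; within the scatter) that stays within the scatter, with no clear direction. The estimate for compound 3 is therefore 40 nM, in the range 15 nM to 120 nM.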

Compound 3, half-maximal inhibitory concentration: 21 nM
Compound 3: middle estimate off by 1.9-fold (0.28 log units), on the high side; low and high end bracket the measured number.
By their numbers in this assay, from the lowest: compounds 3 and 2 (each within the scatter of the next); then compound 1.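

Within the data shown here, on a saturated ring carbon three ring bonds from the ring nitrogen, 3-methyl-2-oxoimidazolidin-1-yl in place of 2,5-dioxopyrrolidin-1-yl gives, in this assay, a 1.7-fold lower number from compound 2 to compound 3 (0.22 log units; within the scatter) and is the only step so far that can be read at a single place. This position therefore accepts either of these five-membered non-aromatic rings with the value staying within the scatter, although the two rings have different counts of ring hetero atoms, double bonds outside aromatic rings and hydrogen-bond acceptors. Both rings have no hydrogen-bond donor and no net charge, so this step says nothing about how the position responds to a group that has either.

Open at this carbon are groups of another kind, such as a primary amine, a carboxylic acid or an open-chain urea, as well as the 2-oxoimidazolidin-1-yl ring without its methyl or with a longer chain in its place. No measurement beyond the values themselves bears on what lies behind this step.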